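Isopropyl for Methyl on Two Related Amide Cores

The source may report more compounds than this note shows. Statements on the series, on what has been measured and on what is new or still open speak of the compounds shown alone.

Compound 1 `C[C@H](NC(=O)c1cc(Cl)ccc1O)C(=O)Nc1ccc(C(F)(F)F)cc1` is assessed in a functional assay on K562 cells (Homo sapiens) for cytotoxicity, with a stated time of 72 h; a lower number here means a stronger inhibitor, a higher number a weaker inhibitor. In this assay compound 1 reaches only the limit > 12500 nM. Compound 2 `CC(C)[C@H](NC(=O)c1cc(Cl)ccc1O)C(=O)Nc1ccc(C(F)(F)F)cc1` gives 4500 nM in this assay, a step of an at least 2.7-fold lower number from compound 1 to compound 2 (0.44 log units; beyond the scatter), the change being (isopropyl in place of methyl on a saturated chain carbon bound to an amide-type nitrogen and a carbonyl carbon). Compound 3 `C[C@H](NC(=O)c1ccc(Cl)cc1O)C(=O)Nc1ccc(Cl)cc1` is built on a different core; the difference between the two cores is not broken down here. In this assay compound 3 reaches only the limit > 10000 nM. Compound 4 `CC(C)[C@H](NC(=O)c1ccc(Cl)cc1O)C(=O)Nc1ccc(Cl)cc1` carries the same kind of change, (isopropyl in place of methyl on a saturated chain carbon bound to an amide-type nitrogen and a carbonyl carbon). Since compound 1 with the limit of > 12500 nM in this assay, at which 1 of the 3 values shown sits, moved to compound 2, a step of similar size is expected for compound 4, namely an at least 2.0-fold lower number from compound 3 to compound 4 (0.30 log units; that floor lies within the scatter). Compound 4 is thus estimated at 5000 nM in this assay, between 2000 nM and 15000 nM.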

Compound 4, half-maximal inhibitory concentration: > 10000 nM
Compound 4 was reported as a limit (the forecaster's own chance of this, stated with the estimate: 35%); middle value at least 2.0-fold (0.30 log units) from the limit.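

For the compounds shown here, compound 3 and compound 4 are both reported only as limits in this assay, so no step between them can be read. As far as these compounds go, whether isopropyl in place of methyl lowers the number on this core remains open.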